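The source may hold more compounds than are shown below. What is called first, only, known or untested is meant among the compounds shown, and "the series" means these compounds.

Measured compounds in hand:
- compound 1 `Fc1ccc(-c2nn3c(NC4CCCC4)cccc3c2-c2ccc3[nH]ccc3c2)cc1` — 20000 nM
- compound 2 `Fc1ccc(-c2nn3c(NC4CCCC4)cccc3c2-c2ccsc2)cc1` — "not determined" (no result reported)
- compound 3 `Fc1ccc(-c2nn3c(NC4CCCC4)cccc3c2-c2ccnnc2)cc1` — "not determined" (no result reported)

In an ADME assay on Vero cells (Chlorocebus sabaeus) for cytotoxicity (on this read-out lower numbers stand for higher toxicity in this test and higher numbers for lower toxicity in this test), compound 1 gives 20000 nM. Among the measured compounds shown here, for compound 2 and compound 3 no number was reported in this assay, so compound 1 stands as the only compound of the series with a measured value, and no step between measured compounds can be drawn from these data. Any comparison therefore has to start from compound 1 alone.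

Compound 4 `Fc1ccc(-c2nn3c(NC4CCCC4)cccc3c2-c2c[nH]c(NC3CCCC3)n2)cc1` differs from compound 1 in one place: 2-(cyclopentylamino)-1H-imidazol-4-yl in place of 1H-indol-5-yl on an aromatic carbon. The shared core and the 4-fluorophenyl group are kept. For the measured compounds named here, with no measured step available, nothing in the data points to a movement in either direction beyond the usual scatter. The expected step is no change at the digits printed from compound 1 to compound 4 (within the scatter), which is meant as no change beyond that scatter. Compound 4 is estimated at 20000 nM in this assay, with a range from 8000 nM to 50000 nM. A report of a limit rather than a number is a real possibility for compound 4.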

Compound 4, half-maximal cytotoxic concentration: 40000 nM
For compound 4 the middle estimate is 2.0-fold (0.30 log units) below the measured one; measured number inside the range.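

At the aromatic carbon next to the ring atom that bears a 4-fluorophenyl group, this assay now gives a first readable step: a 2.0-fold higher number from compound 1 to compound 4 (0.30 log units; within the scatter). At this position, 2-(cyclopentylamino)-1H-imidazol-4-yl, with its five-membered non-aromatic ring of carbon only, can therefore take the place of 1H-indol-5-yl with no change beyond the usual scatter in this test. No measurement on hand bears on the reason for this outcome.

Open, from the compounds shown here alone, is whether a plain amine or a longer chain in place of the cyclopentylamino part of the imidazole group would keep the read-out of this assay within the scatter. Also open, going by these compounds, is whether a carboxylic acid on the 1H-indol-5-yl group would move it beyond the scatter.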